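The source may hold more compounds than are shown below. What is called first, only, known or untested is meant among the compounds shown, and "the series" means these compounds.

Measured compounds:
compound 1 `O=S(=O)(c1cccc(-c2ccc3nccc(-c4ccncc4)c3n2)c1)N1CCC(O)CC1` gives 10000 nM in a physicochemical assay for solubility, read by HPLC, using the shake flask method, measured as kinetic solubility, with a stated time of 20 h, at pH 6.5, tested at 200 uM; a lower number here means a less soluble compound, a higher number a more soluble compound.
compound 2 `O=S(=O)(c1cccc(Nc2ccc3nccc(-c4ccncc4)c3n2)c1)N1CCCC1` gives < 5000 nM in this assay, which is a limit of the assay and not a number.
compound 3 `O=S(=O)(NCCO)c1cccc(-c2ccc3nccc(-c4ccc(OC(F)(F)F)cc4)c3n2)c1` gives < 5000 nM in this assay, again a limit and not a number.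

Going by the values given here, compound 1 is thus the only compound of the three with an actual solubility number; the other two sit at the limit of < 5000 nM in this assay, at which 2 of the 3 values shown sit. Compound 4 `Nc1cccc(-c2ccc3nccc(-c4ccncc4)c3n2)c1` has not been measured in this assay. It differs from compound 1 in one place: amino in place of (4-hydroxypiperidin-1-yl)sulfonyl on an aromatic carbon. Among the compounds with values here, no measured step between compounds is available to calibrate this change. The loss of the (4-hydroxypiperidin-1-yl)sulfonyl group with its hydrogen-bond donor and three acceptors, replaced by the smaller amino, is expected to lower solubility by a modest step, a 2.0-fold lower number from compound 1 to compound 4 (0.30 log units; within the scatter), plausibly beyond the scatter. Compound 4 is accordingly estimated at 5000 nM, within 2000 nM to 15000 nM, with a fair chance that only a limit is reported.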

Compound 4, solubility: < 5000 nM
Compound 4: a limit, no number; the forecaster's own chance of this, stated with the estimate: 40%; the middle value sits exactly at the limit.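

In this assay compound 4 gives a limit and not a number. Amino in place of (4-hydroxypiperidin-1-yl)sulfonyl on an aromatic carbon gives the first step read at this place, an at least 2.0-fold lower number from compound 1 to compound 4 (0.30 log units; that floor lies within the scatter), so the change is bounded on one side only. Most of the set now rests on one floor: the limit of < 5000 nM in this assay, at which 3 of the 4 values shown sit.

On these data alone, how far the amino compound lies beneath that floor stays open. Also open, as far as these compounds go, is whether a carboxylic acid or a longer chain ending in an amine on this carbon would give a number.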